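Trimming the phenoxy headgroup of compound 3

The compounds below may be only part of what the source reports. "The series", "measured", "known", "first", "only" and "open" are said of these compounds alone.

This account follows a single change within a small set of compounds tested in a functional assay (aorta) with Oryctolagus cuniculus as the target; on this read-out higher numbers stand for weaker binding and lower numbers for tighter binding. Compound 1 `COc1cc(C(C)=O)ccc1OCCCN1CCC(C(c2ccc(F)c(F)c2)c2ccc(F)c(F)c2)CC1` and compound 2 `COc1cc(C(C)=O)ccc1OCCCN1CCC(C(c2ccc(Cl)cc2)c2ccc(Cl)cc2)CC1` share a common core and differ only in their halogenated aryl groups; in this assay compound 1 gives 2.51 nM and compound 2 gives 2.51 nM, two values that lie within the scatter of each other. Compound 3 `COc1cc(C(C)O)ccc1OCCCN1CCC(C(c2ccc(F)cc2)c2ccc(F)cc2)CC1` carries a different substituent on its headgroup ring and, in this assay, compound 3 gives 10 nM, the highest of the three numbers and beyond the scatter from both compound 1 and compound 2.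

Compound 4 `Fc1ccc(C(c2ccc(F)cc2)C2CCN(CCCOc3ccccc3)CC2)cc1` has not yet been measured. It differs from compound 3 in one place: phenyl in place of 4-(1-hydroxyethyl)-2-methoxyphenyl on an oxygen on a saturated carbon. For the measured compounds named here, no measured pair shows this change, so its size is open. For compound 4 a step in the direction of weaker binding is expected, a 2.5-fold higher number from compound 3 to compound 4 (0.40 log units; beyond the scatter), with the whole substituted headgroup gone. Compound 4 is therefore estimated at 25 nM, within a range from 8 nM to 80 nM.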

Compound 4, dissociation constant: 1.59 nM
Estimate against measurement, compound 4: 16-fold (1.20 log units) above, and the stated range ends above it.
By their numbers in this assay, from the lowest: compounds 4, 1 and 2 (each within the scatter of the next); then compound 3.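

In this assay, the substituted headgroup on this oxygen proves unnecessary for a low number: phenyl in place of 4-(1-hydroxyethyl)-2-methoxyphenyl gives a 6.3-fold lower number from compound 3 to compound 4 (0.80 log units; beyond the scatter), a step beyond the scatter. The change removes the one hydrogen-bond donor and both hydrogen-bond acceptors of the leaving group, and binding tightens rather than weakens, so this position accepts the bare ring. Nothing measured here explains why the simpler group gives the lower number.

From the compounds shown here alone, whether the step belongs to the methoxy group, to the 1-hydroxyethyl group or to the two together remains open. Also open, going by these compounds, is how the number would move with a small group such as an amine or a carboxylic acid on the phenyl ring of compound 4.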